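The compounds below may be only part of what the source reports. "The series", "measured", "known", "first", "only" and "open" are said of these compounds alone.

Measured so far:
- compound 1, `O=C(O)[C@H]1CCC[C@@H](c2cccc3ccccc23)O1`, 49%
- compound 2, `OC[C@H]1C[C@@H](Cl)C[C@@H](c2cccc3ccccc23)O1`, 87.5%

In a functional assay on the whole organism (Abdomen, strain Swiss albino) for inhibition, with Mus musculus as the target, in the writhing test, with a stated time of 30 min, at a dose of 30 mg/kg by the oral route (on this read-out lower numbers stand for less inhibition and higher numbers for more inhibition at the one dose given (going by the name of the read-out)), compound 2 stands highest of the two numbers; its nearest neighbour is compound 1, which in this assay gives 49%, a gap beyond the usual scatter. Within the data shown here, compound 1 and compound 2 differ in more than one place, so no single step between measured compounds is known, and nothing here separates the effect of the carboxy from that of the chloro group.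

Compound 3, `O=C(O)[C@H]1C[C@@H](Cl)C[C@@H](c2cccc3ccccc23)O1`, is not yet measured. It differs from compound 2 in one way: carboxy in place of hydroxymethyl on a saturated ring carbon

Compound 1 carries the same carboxy and gives 49% in this assay, so a drop beyond the scatter is expected for compound 3, the step from compound 2 being estimated at a number 25.5 percentage points lower from compound 2 to compound 3 (beyond the scatter). For compound 3 in this assay the estimate is 62%, within 38% to 86%.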

Compound 3, a percentage reported as inhibition, in the whole organism at one dose (the size of the read-out at that dose, not a potency): 54.4%
The estimate for compound 3 lay 7.6 percentage points above the measured number; the range from low to high includes it.
By their numbers in this assay, from the lowest: compounds 1 and 3 (each within the scatter of the next); then compound 2.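

In this assay, among these compounds, carboxy in place of hydroxymethyl on a saturated ring carbon, with the chloro group kept, gives a number 33.1 percentage points lower from compound 2 to compound 3 (beyond the scatter) as the first one-place reading at this position. Chloro in place of hydrogen, with the carboxy kept, gives a number 5.4 percentage points higher from compound 1 to compound 3 (within the scatter) and so separates the two changes that compound 1 and compound 2 left tied together: of these two steps, only the one at the carboxy position lies beyond the scatter. No available measurement bears on the reason for the large carboxy step.

Going by these compounds, whether the chloro group matters any more alongside hydroxymethyl than alongside carboxy remains open. Also open, on these data alone, is how a methyl ester, a primary amide or an aminomethyl group at this ring carbon would read in this assay relative to hydroxymethyl and carboxy.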